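Swapping the Aryl Group on the Amide Nitrogen of Compound 1

A few compounds are considered here, and "the series" means these few. Any claim that something is new, unique, unknown or untested is made for them only; others in the source may bear on it.

In a functional assay on FaDu cells (Homo sapiens) for cytotoxicity, read by MTT assay, with a stated time of 72 h (a lower number here means that less compound is tolerated, a higher number that more compound is tolerated), compound 1 `COc1ncc(NC(=O)C(=O)c2cn(C(C)C)c3ccccc23)cn1` gives 171 nM and compound 3 `COc1ccc(NC(=O)C(=O)c2cn(C(C)C)c3ncccc23)cn1` gives 126 nM, and these two numbers lie within the usual scatter of each other. Compound 2 `COCCn1cc(C(=O)C(=O)Nc2ccc(OCC(=O)O)nc2)c2ccccc21` reads > 10000 nM, which is a limit of the assay and not a number. Compound 1 therefore stands level with compound 3, and only these two offer a number for comparison.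

The next compound is compound 4 `COc1ccc(NC(=O)C(=O)c2cn(C(C)C)c3ccccc23)cc1`, with 4-methoxyphenyl in place of 2-methoxypyrimidin-5-yl on an amide-type nitrogen. Going by the values given here, no two measured compounds differ in one place only, so the size of this change has not been seen directly. In this assay, only a small move toward a lower number is expected, within the scatter or scarcely beyond it. The expected step of a 1.9-fold lower number from compound 1 to compound 4 (0.28 log units; within the scatter) is thus a modest one. For compound 4 the estimated value is 90 nM, with an expected range from 30 nM to 270 nM.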

Compound 4, concentration lethal to 50% of the cells: 181 nM
Compound 4: the middle estimate sits 2.0-fold (0.30 log units) below what was measured; the measured number falls inside the stated range.
By their numbers in this assay, from the lowest: compounds 3, 1 and 4 (each within the scatter of the next). At a limit, above all of these: compound 2.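

Swapping 2-methoxypyrimidin-5-yl for 4-methoxyphenyl on the amide-type nitrogen gives the first direct reading of a change at this place: in this assay it amounts to a 1.1-fold higher number from compound 1 to compound 4 (0.02 log units; within the scatter). A ring of carbon only with 1 hydrogen-bond acceptor thus stands in for a ring with 2 hetero atoms and 3 hydrogen-bond acceptors, and the two numbers cannot be told apart. Nothing measured here gives a cause for this result.

On these data alone, both rings carry a methoxy group, so what an amine or a chlorine in its place would do remains open. This single step also leaves open whether the same swap would read alike on the core of compound 3.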